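The compounds below may be only part of what the source reports. "The series", "measured", "known", "first", "only" and "open" are said of these compounds alone.

Measured compounds:
compound 1 `C/C(CN1CCN(c2nc(=O)c3cc(C(F)(F)F)cc([N+](=O)[O-])c3s2)CC1)=N\OCc1ccccc1` — > 64 ug/mL in an ADME assay on Vero cells (Chlorocebus sabaeus) for cytotoxicity; on this read-out lower numbers stand for higher toxicity in this test and higher numbers for lower toxicity in this test
compound 2 `CON=C1CCC(CN2CCN(c3nc(=O)c4cc(C(F)(F)F)cc([N+](=O)[O-])c4s3)C[C@@H]2C)CC1` — > 64 ug/mL
compound 3 `CCON=C1CCC(CN2CCN(c3nc(=O)c4cc(C(F)(F)F)cc([N+](=O)[O-])c4s3)CC2C)CC1` — > 64 ug/mL

Each of these three values is a limit of this assay, not a measured number. Compound 1 therefore stands at the limit of > 64 ug/mL in this assay, at which 3 of the 3 values shown sit, and on these numbers nothing separates it from compound 2 or compound 3. Compound 4 `CCON=C1CC(CN2CCN(c3nc(=O)c4cc(C(F)(F)F)cc([N+](=O)[O-])c4s3)CC2)C1` is not yet measured. It differs from compound 1 by a group of 8 heavy atoms (6 carbon, 1 nitrogen, 1 oxygen; one four-membered non-aromatic ring of carbon only) in place of a group of 11 heavy atoms (9 carbon, 1 nitrogen, 1 oxygen; one six-membered aromatic ring of carbon only), on a saturated chain carbon bound to an amine nitrogen in a ring. For the measured compounds named here, no step between measured compounds exists, so there is nothing to scale the change against; the expectation is no shift beyond the scatter, with compound 4 most likely again reaching the limit. The estimate for compound 4 is 90 ug/mL (range 45 ug/mL to 180 ug/mL), which means an expected step that the limit leaves unreadable from compound 1 to compound 4.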

Compound 4, half-maximal cytotoxic concentration: > 64 ug/mL
Compound 4: a limit, no number; the forecaster's own chance of this, stated with the estimate: 85%; the middle value does not contradict the limit.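

Compound 1 and compound 4 both give only a limit in this assay, so no step between them can be read: the limit of > 64 ug/mL in this assay, at which 4 of the 4 values shown sit.

The compounds shown leave open what actual value any of them has on this read-out, and whether any structural change in the series shifts it.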